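Pyridine for pyrimidine: expected clearance of compound 4

The source may report more compounds than this note shows. Statements on the series, on what has been measured and on what is new or still open speak of the compounds shown alone.

Compound 1 `O=c1n(Cc2nc(-c3nccs3)cn2CCCCO)c2cnccc2n1C1CC1`: in an ADME assay on microsomes from liver (Homo sapiens) for metabolic stability (on this read-out lower numbers stand for slow clearance and higher numbers for fast clearance), compound 1 gives < 8 mL.min-1.g-1, a limit of the assay rather than a number.
Compound 2 `Cn1nccc1-c1cn(CCCCO)c(Cn2c(=O)n(C3CC3)c3ccncc32)n1`: in this assay compound 2 gives < 8 mL.min-1.g-1, also a limit.
Compound 3 `O=c1n(Cc2nc(-c3ncccn3)cn2CCCCO)c2cnccc2n1C1CC1`: in this assay compound 3 gives < 8 mL.min-1.g-1, also a limit.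

Compound 3 therefore stands at the limit, as do the two other values (the limit of < 8 mL.min-1.g-1 in this assay, at which 3 of the 3 values shown sit). Compound 4 `O=c1n(Cc2nc(-c3ccccn3)cn2CCCCO)c2cnccc2n1C1CC1` differs from compound 3 by pyridin-2-yl in place of pyrimidin-2-yl on an aromatic carbon. The measured steps that bear on this change are a step that the two limits leave unreadable from compound 1 to compound 3 and a step that the two limits leave unreadable from compound 2 to compound 3; their size cannot be read, since each end is only a limit. Among the measured compounds shown here, no measured step shows movement beyond the scatter, so the step from compound 3 to compound 4 is expected to be small, a step that the limit leaves unreadable from compound 3 to compound 4. Compound 4 is thus estimated at 5 mL.min-1.g-1, with a range from 2 mL.min-1.g-1 to 12 mL.min-1.g-1, and most likely will again be reported only as a limit.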

Compound 4, intrinsic clearance in microsomes: < 8 mL.min-1.g-1
Compound 4 ended at the assay's limit; the forecaster's own chance of this, stated with the estimate: 75%; the middle value does not contradict the limit.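

Compound 4, like compound 1, compound 2 and compound 3, gives only a limit and not a number, so no step among these compounds can be read: the limit of < 8 mL.min-1.g-1 in this assay, at which 4 of the 4 values shown sit.

From the compounds shown here alone, whether the four compounds truly differ in clearance in this assay remains open.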